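This account rests on a few compounds, and the source may have more. Where it says the series, first, only, none or still open, it means among the compounds named here.

Compound 1 `COC(=O)NS(=O)(=O)c1sc(CC(C)C)cc1-c1cccc(Cn2ccnc2)c1` in an assay on HEK293 cells for displacement of a labelled ligand from Type-2 angiotensin II receptor (Homo sapiens), read by scintillation counting, with a stated time of 240 min (on this read-out higher numbers stand for weaker inhibition and lower numbers for stronger inhibition), gives 400 nM.
Compound 2 `CC(C)Cc1cc(-c2cccc(Cn3ccnc3)c2)c(S(=O)(=O)NC(=O)OC(C)(C)C)s1` in this assay gives 270 nM.

Going by the values given here, compound 2 has the lowest of the two numbers, but its nearest neighbour is compound 1, and the only measured step, a 1.5-fold lower number from compound 1 to compound 2 (0.17 log units; within the scatter), stays within the scatter. So on the numbers so far, compound 2 and compound 1 cannot be told apart in this assay.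

Compound 3 `CCN(CC)C(=O)NS(=O)(=O)c1sc(CC(C)C)cc1-c1cccc(Cn2ccnc2)c1` is not yet measured. Its difference from compound 2 is diethylamino in place of tert-butoxy on a carbonyl carbon. Among the compounds with values here, no measured step bears on this change directly: the one step available, from compound 1 to compound 2, swaps two groups on the oxygen of the carbonyl and shows no movement beyond the scatter. That step gives no direct guidance on exchanging the tert-butoxy for a diethylamino, so the expectation is that compound 3 should stay near compound 2, with a 1.1-fold higher number from compound 2 to compound 3 (0.05 log units; within the scatter) expected to be no change beyond the scatter. For compound 3 the estimated value in this assay is 300 nM, with a range from 100 nM to 900 nM.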

Compound 3, inhibition constant: 2300 nM
For compound 3 the middle estimate is 7.7-fold (0.88 log units) below the measured one, outside the stated range (above it).
By their numbers in this assay, from the lowest: compounds 2 and 1 (each within the scatter of the next); then compound 3.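

Compounds 1 and 2 made this carbonyl carbon look indifferent to change, but they varied only the group on the oxygen. Putting diethylamino in place of either oxygen-linked group does register in this assay, with an 8.5-fold higher number from compound 2 to compound 3 (0.93 log units; beyond the scatter) and a 5.8-fold higher number from compound 1 to compound 3 (0.76 log units; beyond the scatter), both modest but beyond the scatter. Atom count does not separate tert-butoxy from diethylamino, as they have the same number of heavy atoms and neither carries a ring or a net charge, so the loss of inhibition cannot be read from size by that count, and nothing available here gives a measured reason for it.

The compounds shown leave open whether the weaker inhibition goes with the nitrogen on the carbonyl carbon or with the two ethyl groups it carries, since these change together in compound 3. Dimethylamino or ethylamino on the same carbonyl carbon would help separate those two readings, and a pyrrolidine amide would show whether tying the two chains into a ring alters the result.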